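Cytotoxicity notes on a dihydropyrimidinone series

The compounds below may be only part of what the source reports. "The series", "measured", "known", "first", "only" and "open" are said of these compounds alone.

Measured so far:
- compound 1, `O=C1CCCC2=C1C(c1ccc(F)cc1)N=C(c1cccnc1)N2`: 281000 nM
- compound 2, `O=C1CCCC2=C1C(c1ccccc1)N=C(c1cccnc1)N2`: 369000 nM
- compound 3, `CC1(C)CC(=O)C2=C(C1)NC(c1cccnc1)=NC2c1ccc(F)cc1Cl`: 624000 nM

All three were run in an ADME assay on HepG2 2.2.15 cells (Homo sapiens) for cytotoxicity; on this read-out higher numbers stand for weaker inhibition and lower numbers for stronger inhibition. Compound 1 and compound 2 share one core and differ by a single change, (hydrogen in place of fluoro on an aromatic carbon), which gave a 1.3-fold higher number from compound 1 to compound 2 (0.12 log units; within the scatter). Compound 3 sits on a different core; the difference between the two cores is not broken down here. Its number is the highest of the three, but only its gap to compound 1 lies beyond the scatter, while its gap to compound 2 does not, so no ordering of compound 2 and compound 3 is claimed.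

Compound 4, `CC1(C)CC(=O)C2=C(C1)NC(c1cccnc1)=NC2c1ccccc1Cl`, has not yet been measured. It differs from compound 3 by hydrogen in place of fluoro on an aromatic carbon. This is the same kind of change as that from compound 1 to compound 2: in both cases fluoro leaves an aromatic carbon para to a large group, but in compound 3 that carbon is also meta to a chloro group, so the surroundings are not identical. On the one worked example, where the change was a 1.3-fold higher number from compound 1 to compound 2 (0.12 log units; within the scatter), compound 4 is expected to show a step of about a 1.2-fold higher number from compound 3 to compound 4 (0.08 log units; within the scatter) from compound 3, that is, no movement outside the scatter. The estimate for compound 4 in this assay is therefore 750000 nM, with an expected range from 350000 nM to 1600000 nM.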

Compound 4, half-maximal inhibitory concentration: 67300 nM
Compound 4: middle estimate off by 11-fold (1.05 log units), on the high side, and the stated range ends above it.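

In this assay, going from 2-chloro-4-fluorophenyl to 2-chlorophenyl gave a 9.3-fold lower number from compound 3 to compound 4 (0.97 log units; beyond the scatter), a clear step on a core where the same exchange might have been expected to do little. The exchange of fluoro for hydrogen on this aromatic carbon therefore does not carry over unchanged between the two cores of this series: the same change on two cores in this assay, a 1.3-fold higher number (0.12 log units; within the scatter) from compound 1 to compound 2 and a 9.3-fold lower number (0.97 log units; beyond the scatter) from compound 3 to compound 4, 12-fold (1.09 log units) apart, beyond the scatter of two such steps. This rests on a single pair on each core, so it shows that the step measured on one core cannot stand in for the step on the other, but it does not show which difference in the surroundings is responsible, and it gives no rule for any further core.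

The two pairs differ both in the chloro group on the aromatic ring and in the rest of the core, and the compounds shown do not separate these, so a pair carrying 2-chlorophenyl and phenyl on the core of compound 1 would be the direct comparison. Also open, on these data alone, is how a methoxy group, an amine or a nitrile at the same aromatic carbon would behave on either core, and whether the step on the core of compound 3 would hold for such groups.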